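Cyanophenyl isomer step from compound 3 to compound 4

A few compounds are considered here, and "the series" means these few. Any claim that something is new, unique, unknown or untested is made for them only; others in the source may bear on it.

- compound 1 `COc1cc2c(Nc3cccc(C#N)c3)ncnc2cc1OCCCN1CCC(C)CC1` with 24400 nM
- compound 2 `COc1cc2c(Nc3cccc(C#N)c3)ncnc2cc1OCCCN1CCN(C)CC1` with 23100 nM
- compound 3 `CCN1CCN(CCCOc2cc3ncnc(Nc4cccc(C#N)c4)c3cc2OC)CC1` with 20000 nM

These values come from a functional assay on MCF7 cells (Homo sapiens) for antiproliferative activity, read by MTT assay, with a stated time of 72 h (a higher number here means a weaker inhibitor, a lower number a stronger inhibitor), and do not separate compound 3 from the other two compounds. The steps of a 1.2-fold lower number from compound 2 to compound 3 (0.06 log units; within the scatter) and a 1.2-fold lower number from compound 1 to compound 3 (0.09 log units; within the scatter) lie within the scatter, as does a 1.1-fold lower number from compound 1 to compound 2 (0.02 log units; within the scatter) as well.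

The next compound is compound 4 `CCN1CCN(CCCOc2cc3ncnc(Nc4ccccc4C#N)c3cc2OC)CC1` and the change is 2-cyanophenyl in place of 3-cyanophenyl on a nitrogen on an aromatic ring in full: 2-cyanophenyl in place of 3-cyanophenyl on a nitrogen on an aromatic ring. Within the data shown here, none of the measured steps touches this group. All three exchange the 4-methylpiperidin-1-yl, 4-methylpiperazin-1-yl and 4-ethylpiperazin-1-yl ends of the chain, while 3-cyanophenyl stays constant. They therefore bear on the new step only indirectly, and the data hold no measured change at the cyanophenyl group.

Among the measured compounds shown here, with no measured step to suggest a direction, the working expectation is no step beyond the scatter, starting from compound 3 at 20000 nM in this assay and with a wide margin on both sides. The estimated change is a 1.1-fold higher number from compound 3 to compound 4 (0.04 log units; within the scatter) as a best guess. For compound 4 the expected value is 22000 nM in this estimate. The expected range for compound 4 runs from 9000 nM to 50000 nM in this assay for now.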

Compound 4, half-maximal inhibitory concentration: 9070 nM
Estimate against measurement, compound 4: 2.4-fold (0.38 log units) above; the measured number falls inside the stated range.
By their numbers in this assay, from the lowest: compound 4; then compounds 3, 2 and 1 (each within the scatter of the next).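

In this assay, exchanging 3-cyanophenyl for 2-cyanophenyl on the nitrogen gives a 2.2-fold lower number from compound 3 to compound 4 (0.34 log units; beyond the scatter), a modest step but the first in this series beyond the scatter, since the three exchanges at the chain end among compounds 1, 2 and 3 all stayed within it. The two groups have the same atoms and the same counts of donors, acceptors and rings, so the readout responds here to how the same atoms are joined, with no change in composition, and this position on the anilino side of the series is more informative than the end of the chain has been so far. No supporting measurement accompanies this result, so the step stands as an observation without an explanation.

The compounds shown leave open whether the step from 3-cyanophenyl to 2-cyanophenyl carries over to the 4-methylpiperazin-1-yl or 4-methylpiperidin-1-yl chain ends, or whether it belongs to the 4-ethylpiperazin-1-yl pair alone. They also leave open how an unsubstituted phenyl, or an amide or a carboxylic acid in place of the nitrile, would compare with 2-cyanophenyl on the same nitrogen.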